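Replacing 3,4,5-trimethoxyphenyl with 4-ethoxyphenyl in compound 2

The source may hold more compounds than are shown below. What is called first, only, known or untested is meant among the compounds shown, and "the series" means these compounds.

- compound 1 `CCOc1ccc(/C=C/C(=O)Nc2ccc(NC(=O)[C@@H](O)[C@H](N)CC3CCCCC3)cc2)cc1` gives 1000 nM
- compound 2 `COc1cc(/C=C/C(=O)Nc2ccc(NC(=O)[C@@H](O)[C@H](N)CCc3ccccc3)cc2)cc(OC)c1OC` gives 850 nM
- compound 3 `COc1cc(/C=C/C(=O)Nc2ccc(NC(=O)[C@@H](O)[C@H](N)CCc3ccccc3)c(C)c2)cc(OC)c1OC` gives 2300 nM

In a functional assay on HUVEC cells (Homo sapiens) for antiproliferative activity (on this read-out lower numbers stand for stronger inhibition of growth and higher numbers for weaker inhibition of growth), compound 2 and compound 1 lie within the scatter of each other, and compound 3 stands higher, beyond the scatter. Compound 4 `CCOc1ccc(/C=C/C(=O)Nc2ccc(NC(=O)[C@@H](O)[C@H](N)CCc3ccccc3)cc2)cc1` departs from compound 2 in one place: 4-ethoxyphenyl in place of 3,4,5-trimethoxyphenyl on a double-bonded chain carbon bound to a double-bonded chain carbon. Within the data shown here, the only measured step, a 2.7-fold higher number from compound 2 to compound 3 (0.43 log units; beyond the scatter), is a methyl in place of hydrogen on an aromatic carbon, a different change that offers no direct guide here. Differing elsewhere from compound 4 but also carrying 4-ethoxyphenyl, compound 1 gives 1000 nM in this assay. No change beyond the scatter is therefore expected, and the estimated step is a 1.1-fold higher number from compound 2 to compound 4 (0.02 log units; within the scatter). Compound 4 is expected at 900 nM, with an estimated range of 350 nM to 2500 nM.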

Compound 4, concentration for 50% growth inhibition: 1800 nM
The estimate for compound 4 lay 2.0-fold (0.30 log units) below the measured number; the range from low to high includes it.
By their numbers in this assay, from the lowest: compounds 2, 1, 4 and 3 (each within the scatter of the next, the first and the last beyond it).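

In this assay, 4-ethoxyphenyl in place of 3,4,5-trimethoxyphenyl on a double-bonded chain carbon bound to a double-bonded chain carbon gives a 2.1-fold higher number from compound 2 to compound 4 (0.33 log units; beyond the scatter), so this position responds to the change when the rest of the molecule stays fixed. Benzyl in place of cyclohexyl gives a 1.8-fold higher number from compound 1 to compound 4 (0.26 log units; within the scatter), a step that stays inside the scatter. No measurement at hand accounts for either step.

On these data alone, whether 4-methoxyphenyl or a carboxylic acid in this place would keep or lose growth inhibition remains open.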